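From 3-cyanophenyl to 1-benzofuran-4-yl on the shared core

The source may hold more compounds than are shown below. What is called first, only, known or untested is meant among the compounds shown, and "the series" means these compounds.

Measured in a physicochemical assay for solubility; on this read-out higher numbers stand for higher solubility and lower numbers for lower solubility:
- compound 1 `CNC(=O)c1cc(C(=O)NC2CC2)cn(CC2CCCCC2)c1=O`: >= 148 ug/mL
- compound 2 `CNC(=O)c1cc(C(=O)NC2CC2)cn(Cc2ccc3nc[nH]c3c2)c1=O`: >= 163 ug/mL
- compound 3 `CNC(=O)c1cc(C(=O)NC2CC2)cn(Cc2cccc(C#N)c2)c1=O`: >= 148 ug/mL

All three entries are limits, not numbers. Compound 3 stands at the limit of >= 148 ug/mL in this assay, at which 2 of the 3 values shown sit.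

The next exchange, to compound 4 `CNC(=O)c1cc(C(=O)NC2CC2)cn(Cc2cccc3occc23)c1=O`, falls on a saturated chain carbon bound to an aromatic nitrogen: 1-benzofuran-4-yl in place of 3-cyanophenyl on a saturated chain carbon bound to an aromatic nitrogen.

Two measured exchanges at the same place bear on it: a step that the two limits leave unreadable from compound 1 to compound 3 and a step that the two limits leave unreadable from compound 2 to compound 3. Neither has a size to carry over, and the same holds for a step that the two limits leave unreadable from compound 1 to compound 2. With the limit of compound 3 at >= 148 ug/mL, only a modest drop or no readable step is expected in this assay. The estimated change is an at least 1.1-fold lower number from compound 3 to compound 4 (0.05 log units; that floor lies within the scatter). For compound 4 the expected value is 130 ug/mL, with an estimated range of 40 ug/mL to 165 ug/mL.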

Compound 4, solubility: >= 110 ug/mL
Compound 4: a limit, no number; the forecaster's own chance of this, stated with the estimate: 50%; the middle value is on the limit's open side.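

In this assay compound 4 gives >= 110 ug/mL, a limit. Within the data shown here, compounds 1, 2 and 3 also stand as limits, so no step to compound 4 can be read. The compounds shown leave open where the actual values of all four lie and how they rank.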